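The compounds below may be only part of what the source reports. "The series", "measured", "known", "first", "only" and "open" are said of these compounds alone.

Measured compounds:
Compound 1, `COc1ccccc1-c1ncnn1-c1cc(OC)c(OC)c(OC)c1`. In a functional assay on MCF7 cells (Homo sapiens) for antiproliferative activity, read by MTT assay, with a stated time of 72 h (on this read-out lower numbers stand for stronger inhibition and higher numbers for weaker inhibition), compound 1 gives > 10000 nM, which is a limit of the assay rather than a number.
Compound 2, `CCOc1ccccc1-c1ncnn1-c1cc(OC)c(OC)c(OC)c1`. In this assay compound 2 gives > 10000 nM, again a limit of the assay rather than a number.

Compound 1 therefore stands at the limit of this assay, and the limit of > 10000 nM in this assay, at which 2 of the 2 values shown sit, shows that every value obtained so far sits at that same limit. Going by the values given here, the single step that has been measured, a step that the two limits leave unreadable from compound 1 to compound 2, cannot be read in size, so it offers no calibration.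

Compound 3, `COc1cc(-n2ncnc2-c2cccc(Cl)c2)cc(OC)c1OC`, differs from compound 1 by 3-chlorophenyl in place of 2-methoxyphenyl on an aromatic carbon. Among the compounds with values here, no measured step touches this part of the shared core, so nothing in the data says whether a 3-chlorophenyl in place of a 2-methoxyphenyl moves the value in this assay in either direction. Within the data shown here, the only guide is that both measured compounds sit at the limit.

For compound 3 the estimate is therefore 8000 nM, spanning 800 nM to 30000 nM. The step this implies, an at least 1.2-fold lower number from compound 1 to compound 3 (0.09 log units; that floor lies within the scatter), is expected to stay close to the limit, with a real chance that compound 3 also returns only a limit.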

Compound 3, half-maximal inhibitory concentration: > 10000 nM
Compound 3: no number, only a limit; the forecaster's own chance of this, stated with the estimate: 55%; middle value at least 1.2-fold (0.09 log units) away from the limit.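

In this assay compound 3 gives > 10000 nM which is a limit of the assay rather than a number, so its step from compound 1 cannot be read in size. What stays open is whether any change to the shared core can give a value that reads as a number, and the results so far offer no hint: the limit of > 10000 nM in this assay, at which 3 of the 3 values shown sit.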